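Swapping a fluorinated aryl for a plain alkyl chain

The compounds below may be only part of what the source reports. "The series", "measured", "known", "first", "only" and "open" are said of these compounds alone.

Measured compounds:
compound 1 `COC(=O)N(C)c1c(N)nc(-c2nc(Cc3ccccc3F)n3ccccc23)nc1N`: 20400 nM
compound 2 `CC1(C)C(=O)Nc2nc(-n3nc(Cc4c(F)ccc(F)c4F)c4ccccc43)nc(N)c21`: 2000 nM
compound 3 `CC1(C)C(=O)Nc2nc(-n3nc(Cc4ccccc4F)c4cc(Cl)ccc43)nc(N)c21`: 18000 nM

In an assay on CHO cells for activation of soluble guanylate cyclase alpha1/beta1 complex (Homo sapiens), read by cGMP accumulation (on this read-out higher numbers stand for an effect only at larger amounts of compound and lower numbers for an effect already at smaller amounts), compound 3 gives 18000 nM, the second highest of the three numbers. Compound 1 sits within the usual scatter of it, so the two cannot be told apart. Compound 2 gives 2000 nM, a gap that lies beyond the scatter. Compound 4 `CCCCCc1nn(-c2nc(N)c3c(n2)NC(=O)C3(C)C)c2ccc(Cl)cc12` has not yet been measured. It differs from compound 3 in one place: butyl in place of 2-fluorophenyl on a saturated chain carbon bound to an aromatic carbon. Among the compounds with values here, no measured pair shows this kind of change, so the direction rests on judgement alone. Compound 4 is expected to give a somewhat higher number, a step from compound 3 to compound 4 of a 2.2-fold higher number from compound 3 to compound 4 (0.35 log units; beyond the scatter). The estimate for compound 4 is 40000 nM, with a range from 8000 nM to 200000 nM.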

Compound 4, half-maximal effective concentration: 90000 nM
Beside the measured number, compound 4's estimate is 2.3-fold (0.35 log units) below it, and the stated range covers the measured number.
By their numbers in this assay, from the lowest: compound 2; then compounds 3 and 1 (each within the scatter of the next); then compound 4.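

In this assay, butyl in place of 2-fluorophenyl on a saturated chain carbon bound to an aromatic carbon gives a 5.0-fold higher number from compound 3 to compound 4 (0.70 log units; beyond the scatter). Within the data shown here, this is the first measured change at this position, and it shows that the position responds to what is placed there: the plain alkyl chain does not match the fluorinated aryl group. Nothing measured explains the size of this step. A shorter chain such as ethyl, a longer chain such as octyl, or an amine at the chain end could each give a different number. Going by these compounds, how a plain phenyl compares also stays open.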